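The source may report more compounds than this note shows. Statements on the series, on what has been measured and on what is new or still open speak of the compounds shown alone.

Values measured in a physicochemical assay for solubility, read by spectrophotometry, in phosphate buffer, measured as kinetic solubility, with a stated time of 18 h, at pH 7.4; a lower number here means a less soluble compound, a higher number a more soluble compound:

- compound 1 `O=C(Nc1ccc(F)c(-c2nc3ccccc3o2)c1)c1cc([N+](=O)[O-])ccc1Cl`: 270 nM
- compound 2 `O=C(Nc1cccc(-c2nc3ccccc3s2)c1)c1cc([N+](=O)[O-])c(O)cc1Cl`: 2200 nM
- compound 3 `O=C(Nc1ccc(F)c(-c2nc3ccccc3s2)c1)c1cc([N+](=O)[O-])ccc1Cl`: 490 nM

Compound 3 and compound 1 cannot be told apart on these numbers, while compound 2 stands above compound 3 by more than the usual scatter.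

The next compound to be measured is compound 4 `O=C(Nc1cccc(-c2nc3ccccc3s2)c1)c1cc([N+](=O)[O-])ccc1Cl`, which makes one change to compound 3: hydrogen in place of fluoro on an aromatic carbon. This puts hydrogen in place of fluoro on an aromatic carbon, ortho to the 1,3-benzothiazol-2-yl group.

Going by the values given here, no measured step makes this change on its own. Among the compounds with values here, the only single-place step, a 1.8-fold higher number from compound 1 to compound 3 (0.26 log units; within the scatter), swaps 1,3-benzoxazol-2-yl for 1,3-benzothiazol-2-yl elsewhere in the molecule, so it offers only a loose guide to size. It does show that one small swap in this set need not move the number beyond the scatter. Compound 2, at 2200 nM, also has hydrogen at this place, but it carries an extra hydroxy group as well. Its higher value therefore cannot be credited to the loss of fluoro, and it only stretches the upper end of the range.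

In this assay, no shift beyond the scatter is expected, and the estimated step is a 1.1-fold higher number from compound 3 to compound 4 (0.05 log units; within the scatter). For compound 4 the estimated value is 550 nM, with an expected range of 230 nM to 1300 nM.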

Compound 4, solubility: 580 nM
Beside the measured number, compound 4's estimate is 1.1-fold (0.02 log units) below it; the measured number falls inside the stated range.
By their numbers in this assay, from the lowest: compounds 1, 3 and 4 (each within the scatter of the next, the first and the last beyond it); then compound 2.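

In this assay, putting hydrogen in place of fluoro on the aromatic carbon ortho to the 1,3-benzothiazol-2-yl group gives a 1.2-fold higher number from compound 3 to compound 4 (0.07 log units; within the scatter), so on these numbers the two compounds cannot be told apart and this position takes either atom without a readable change. Compound 4 also gives compound 2 a partner that differs in one place only, and hydrogen in place of hydroxy gives a 3.8-fold lower number from compound 2 to compound 4 (0.58 log units; beyond the scatter), so the step beyond the scatter between these two compounds lies at the hydroxy position and not at the fluoro position. Nothing in the data shown explains why either step has the size it has.

At the position ortho to the 1,3-benzothiazol-2-yl group, the compounds shown carry only hydrogen and fluoro, so it remains open whether a larger group such as methoxy or an amine would also stay within the scatter. As far as these compounds go, it is also open whether the fluoro-to-hydrogen change would read the same alongside other groups: compound 2 shows the hydroxy group only with hydrogen, and compound 1 shows the 1,3-benzoxazol-2-yl group only with fluoro.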